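From bromo to methoxy on the aromatic ring

A few compounds are considered here, and "the series" means these few. Any claim that something is new, unique, unknown or untested is made for them only; others in the source may bear on it.

Measured so far in a functional assay on MDA-MB-231 cells (Homo sapiens) for antiproliferative activity, read by MTT assay, with a stated time of 72 h; on this read-out lower numbers stand for stronger inhibition and higher numbers for weaker inhibition:
- Compound 1 `NC1=NC2(CCSCC2)N(OCCCOc2ccc(Br)cc2)C(N)=N1` gives 440 nM
- Compound 2 `NC1=NC2(CCOCC2)N(OCCCOc2cccc(Cl)c2)C(N)=N1` gives 1020 nM

Compound 1 has the lower of these two numbers, and compound 2 sits higher by more than the usual scatter. Compound 3 `COc1ccc(OCCCON2C(N)=NC(N)=NC23CCSCC3)cc1` has not yet been measured. It differs from compound 1 in one place: methoxy in place of bromo on an aromatic carbon with methoxy in place of bromo on an aromatic carbon, para to a large group. Going by the values given here, no measured pair shows this swap, so the evidence is thin. In this assay the expected step of a 1.6-fold higher number from compound 1 to compound 3 (0.20 log units; within the scatter) is small, towards weaker inhibition, and may stay within the scatter. Compound 3 is expected at 700 nM (estimated range 250 nM to 1900 nM).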

Compound 3, half-maximal inhibitory concentration: 350 nM
Compound 3: the middle estimate sits 2.0-fold (0.30 log units) above what was measured; low and high end bracket the measured number.
By their numbers in this assay, from the lowest: compounds 3 and 1 (each within the scatter of the next); then compound 2.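

In this assay methoxy in place of bromo on an aromatic carbon, para to a large group, gives a 1.3-fold lower number from compound 1 to compound 3 (0.10 log units; within the scatter) and so leaves the two compounds indistinguishable. This place on the ring therefore takes either group, even though methoxy brings one more heavy atom and a hydrogen-bond acceptor. No measurement at hand explains this match.

From the compounds shown here alone, whether an amine, a carboxylic acid or a longer chain such as butoxy would fare the same here remains open. This single pair also cannot show whether the match holds with other groups elsewhere on the compound.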